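The source may report more compounds than this note shows. Statements on the series, on what has been measured and on what is new or still open speak of the compounds shown alone.

Measured compounds in hand:
- compound 1 `Cn1ncc2c(=O)n(-c3ccccc3)c(SC(C)(C)c3ccccc3)nc21`: 1390 nM
- compound 2 `CC(Sc1nc2nn(C3COC3)cc2c(=O)n1-c1ccccc1)c1ccccn1`: 480 nM
- compound 3 `Cn1ncc2c(=O)n(-c3ccccc3)c(CCc3cccc(F)c3)nc21`: 2500 nM

In an assay on isolated protein for inhibition of Retinaldehyde dehydrogenase 3 (Homo sapiens) (a higher number here means a weaker inhibitor, a lower number a stronger inhibitor), compound 1 gives 1390 nM, the second highest of the three numbers. Compound 3 sits nearest, with a number that is within the scatter of compound 1, so the two are not separated here. Compound 2 stands furthest, with a lower number that lies beyond the scatter, and compound 2 is the only one of the three whose step to compound 1 is clearly resolved.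

The next compound, compound 4 `C[C@@H](Sc1nc2c(cnn2C)c(=O)n1-c1ccccc1)c1ccccc1`, has not yet been measured in this assay. It differs from compound 1 in one place: 1-phenylethyl in place of 1-methyl-1-phenylethyl on a sulfur. Among the measured compounds shown here, no measured pair in the set shows this change on its own, so its effect cannot be read off directly. Compound 2 carries a related 1-substituted ethyl on the same sulfur and gives 480 nM, which is the only hint available.

Expectation for compound 4: a modest move in this assay toward a lower number, with the step from compound 1 expected to be a 2.1-fold lower number from compound 1 to compound 4 (0.33 log units; beyond the scatter), though a result within the scatter of compound 1 would not surprise. The estimate for compound 4 is 650 nM, with a range from 220 nM to 2000 nM.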

Compound 4, half-maximal inhibitory concentration: 34 nM
Estimate against measurement, compound 4: 19-fold (1.28 log units) above; the whole stated range lies above it.
By their numbers in this assay, from the lowest: compound 4; then compound 2; then compounds 1 and 3 (each within the scatter of the next).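

In this assay, the substituent on the sulfur proves highly sensitive: 1-phenylethyl in place of 1-methyl-1-phenylethyl gives a 41-fold lower number from compound 1 to compound 4 (1.61 log units; beyond the scatter) as a large step, even though both groups keep one six-membered aromatic ring of carbon only. The entering group also has one defined stereocentre, so this single step joins the removal of a methyl group with a fixed configuration, and the two cannot be separated here. Nothing available explains the size of the step.

The compounds shown leave open how much of the gain depends on the configuration of compound 4, which only its mirror-image counterpart could settle. They also leave open whether the position tolerates a longer chain such as 1-phenylpropyl, or a carboxylic acid on the phenyl ring of the 1-phenylethyl group.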